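The source may hold more compounds than are shown below. What is called first, only, known or untested is meant among the compounds shown, and "the series" means these compounds.

Measured so far:
Compound 1, `CC(O)(C(=O)Nc1ccc(S(=O)(=O)c2ccccc2Cl)cc1)C(F)(F)F`, in a functional assay (Cavia porcellus) with sulfonylurea receptors; K-ATP channels (Homo sapiens) as the target; on this read-out lower numbers stand for stronger inhibition and higher numbers for weaker inhibition: 2300 nM
Compound 2, `Cc1ccccc1S(=O)(=O)c1ccc(NC(=O)C(C)(O)C(F)(F)F)cc1`, in this assay: 5100 nM
Compound 3, `CC(O)(C(=O)Nc1ccc(C(=O)c2ccccc2)cc1Cl)C(F)(F)F`, in this assay: > 30000 nM, which is a limit of the assay and not a number.

Between compound 1 and compound 2 the change is methyl in place of chloro on an aromatic carbon, and it brought a 2.2-fold higher number from compound 1 to compound 2 (0.35 log units; beyond the scatter). Compound 3 sits at the limit of > 30000 nM in this assay, at which 1 of the 3 values shown sits. How the core of compound 3 differs from the core of compound 1 is not broken down here.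

Compound 4, `Cc1cc(C(=O)c2ccccc2)ccc1NC(=O)C(C)(O)C(F)(F)F`, carries the same kind of change against compound 3: methyl in place of chloro on an aromatic carbon. Here the place is also meta to a benzoyl group, so the surroundings are not identical.

The earlier step weakened inhibition, and compound 3 already gives only a limit, so compound 4 is expected to show a step that the limit leaves unreadable from compound 3 to compound 4. Compound 4 is therefore estimated at 60000 nM, between 20000 nM and 200000 nM.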

Compound 4, half-maximal inhibitory concentration: 5000 nM
Compound 4: middle estimate off by 12-fold (1.08 log units), on the high side; measured number outside the range, below it.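

Methyl in place of chloro on an aromatic carbon brought an at least 6.0-fold lower number from compound 3 to compound 4 (0.77 log units; beyond the scatter), so inhibition in this assay grew stronger with this change on this core. Compound 3 gives > 30000 nM, which is a limit of the assay and not a number. These two pairs show that the change does not carry over unchanged from one core to the other, but not which feature of the cores is responsible: the same change on two cores in this assay, a 2.2-fold higher number (0.35 log units; beyond the scatter) from compound 1 to compound 2 and an at least 6.0-fold lower number (0.77 log units; beyond the scatter) from compound 3 to compound 4, at least 13-fold (1.12 log units) apart, beyond the scatter of two such steps

On these data alone, it remains open how a fluoro or a methoxy group in the same place would behave on either core. As far as these compounds go, it also remains open which difference between the two cores decides the direction of the step.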